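The source may hold more compounds than are shown below. What is called first, only, known or untested is meant among the compounds shown, and "the series" means these compounds.

Measured compounds:
compound 1, `COc1cc(N(CC2CC2)c2ccc(Cl)c(Cl)c2)cnc1C(=O)[C@H]1C[C@@H]1C(=O)O`, with 27.7 nM in an assay on isolated protein for inhibition of leukotriene C4 synthase (Homo sapiens), read by LC-MS, with stated times of 45 min and 20 min; on this read-out lower numbers stand for stronger inhibition and higher numbers for weaker inhibition
compound 2, `COc1cc(N(CC2CC2)c2cc(Cl)ccc2F)cnc1C(=O)[C@H]1C[C@@H]1C(=O)O`, with 34.3 nM in this assay

Compound 2 gives the highest of the two numbers shown, though the gap to compound 1 is small: a 1.2-fold higher number from compound 1 to compound 2 (0.09 log units; within the scatter). The two compounds therefore cannot be told apart on these data.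

Compound 3, `COc1cc(N(CC2CC2)c2cc(Cl)c(F)cc2F)cnc1C(=O)[C@H]1C[C@@H]1C(=O)O`, has not yet been measured. It differs from compound 2 in one place: fluoro in place of hydrogen on an aromatic carbon. Within the data shown here, the only measured step, from compound 1 to compound 2, exchanges one halogenated phenyl group for another on the same nitrogen and stays within the scatter; it is the nearest guide to a further change of halogen pattern on that ring, but it does not cover an added fluoro directly. Among the measured compounds shown here, with no step in hand that bears on this change, no shift beyond the scatter is expected in this assay, in either direction. The step from compound 2 to compound 3 is therefore estimated as a 1.0-fold higher number from compound 2 to compound 3 (0.01 log units; within the scatter). Compound 3 is expected to give about 35 nM, within a range from 15 nM to 80 nM.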

Compound 3, half-maximal inhibitory concentration: 27.6 nM
For compound 3 the middle estimate is 1.3-fold (0.10 log units) above the measured one, and the stated range covers the measured number.
By their numbers in this assay, from the lowest: compounds 3, 1 and 2 (each within the scatter of the next).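

In this assay, compound 3 gives a direct reading of an added halogen on this ring, which compound 1 and compound 2 could not give: fluoro in place of hydrogen on an aromatic carbon, ortho to a chloro group, meta to a fluoro group and para to a large group, gives a 1.2-fold lower number from compound 2 to compound 3 (0.09 log units; within the scatter). The exchange of 3,4-dichlorophenyl for 5-chloro-2,4-difluorophenyl on the same nitrogen gives a 1.0-fold lower number from compound 1 to compound 3 (0.00 log units; within the scatter), so all three halogen patterns shown remain indistinguishable on these data. Nothing in the information at hand offers an explanation for this result.

Going by these compounds, all three compounds carry only chloro and fluoro groups on this ring, so it remains open whether a methoxy group, a trifluoromethyl group, a nitrile or an amine in this position would move the number beyond the scatter. The carboxylic acid is also common to all three, leaving open what an amide or a longer chain in its place would do in this assay.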